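Tert-butyl to ethyl in the series

The source may hold more compounds than are shown below. What is called first, only, known or untested is meant among the compounds shown, and "the series" means these compounds.

For the measured compounds named here, in a physicochemical assay for solubility, in phosphate buffer, at pH 6.8 (a higher number here means a more soluble compound, a lower number a less soluble compound), compound 2 (`CCn1c(NC(C)(C)C)nc2ccsc2c1=O`) reads 3.7 ug/mL as the lower of the two numbers so far, while compound 1 (`CCn1c(NC2CC2)nc2ccsc2c1=O`) reads 430 ug/mL on the same scale. Compound 3 (`CCNc1nc2ccsc2c(=O)n1CC`) brings ethyl in place of tert-butyl on a nitrogen on an aromatic ring. Going by the values given here, the only measured step bearing on this is the large one a 120-fold lower number from compound 1 to compound 2 (2.07 log units; beyond the scatter) (tert-butyl in place of cyclopropyl). Among the compounds with values here, a large rise is therefore expected, though no measured compound carries ethyl there. The estimated step in this assay is a 68-fold higher number from compound 2 to compound 3 (1.83 log units; beyond the scatter) (a rise beyond the scatter). For compound 3 the estimated value is 250 ug/mL (expected range 60 ug/mL to 900 ug/mL).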

Compound 3, solubility: 240 ug/mL
Compound 3: the middle estimate sits 1.0-fold (0.02 log units) above what was measured; the range from low to high includes it.
By their numbers in this assay, from the lowest: compound 2; then compounds 3 and 1 (each within the scatter of the next).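

In this assay the low number belongs to tert-butyl alone among the three groups on this nitrogen, as the step of a 65-fold higher number from compound 2 to compound 3 (1.81 log units; beyond the scatter) shows. Ethyl and cyclopropyl cannot be told apart, since a 1.8-fold lower number from compound 1 to compound 3 (0.25 log units; within the scatter) stays inside the usual variation between repeats. Nothing measured accounts for the gap between tert-butyl and the other two groups. Still open, as far as these compounds go, is where isopropyl or a longer chain such as n-butyl would fall on this nitrogen. Also open, from the compounds shown here alone, is whether a chain ending in a hydroxyl or an amine would read with ethyl or with tert-butyl.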